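Changing the Aryl Arm on the Ring Amine

The source may hold more compounds than are shown below. What is called first, only, known or untested is meant among the compounds shown, and "the series" means these compounds.

Compound 1 `O=C(O)c1ccc(CN2CCC[C@H](OCc3cc(Cl)cc(Cl)c3)[C@@H]2c2ccccc2)s1`: 76000 nM
Compound 2 `CN1CCC[C@H](OCc2cc(Cl)cc(Cl)c2)[C@@H]1c1ccccc1`: > 200000 nM
Compound 3 `Clc1cc(Cl)cc(CO[C@H]2CCCN(Cc3ncc[nH]3)[C@H]2c2ccccc2)c1`: 47000 nM

In an assay on isolated protein for activation of cGMP-dependent protein kinase 1 (Homo sapiens), read by ADP-Glo, with stated times of 120 min and 40 min (on this read-out lower numbers stand for an effect already at smaller amounts and higher numbers for an effect only at larger amounts of compound), compound 1 gives 76000 nM, the highest of the two numbers shown. Compound 3 sits nearest, with a step of a 1.6-fold lower number from compound 1 to compound 3 (0.21 log units; within the scatter). The value of compound 2 is a limit, not a number, as the limit of > 200000 nM in this assay, at which 1 of the 3 values shown sits, shows. Compound 4 `Clc1cc(Cl)cc(CO[C@H]2CCCN(Cc3ccncc3)[C@H]2c2ccccc2)c1` differs from compound 1 in pyridin-4-yl in place of 5-carboxythiophen-2-yl on a saturated chain carbon bound to an amine nitrogen in a ring. Among the compounds with values here, two measured steps bear on this: taking the group away entirely gave an at least 2.6-fold higher number from compound 1 to compound 2 (0.42 log units; beyond the scatter), whereas exchanging it for a different small aromatic heterocycle gave a 1.6-fold lower number from compound 1 to compound 3 (0.21 log units; within the scatter). Since pyridin-4-yl keeps an aromatic ring with one acceptor, compound 4 is expected to change little, roughly a 1.1-fold lower number from compound 1 to compound 4 (0.04 log units; within the scatter). The estimate for compound 4 is 70000 nM, within 25000 nM to 200000 nM.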

Compound 4, half-maximal effective concentration: > 200000 nM
Compound 4: no number, only a limit; the forecaster's own chance of this, stated with the estimate: 20%; at least 2.8-fold (0.45 log units) between middle value and limit.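

The result for compound 4 is a limit, not a number: the limit of > 200000 nM in this assay, at which 2 of the 4 values shown sit. Pyridin-4-yl in place of 5-carboxythiophen-2-yl gives an at least 2.6-fold higher number from compound 1 to compound 4 (0.42 log units; beyond the scatter), and in place of 1H-imidazol-2-yl it gives an at least 4.2-fold higher number from compound 3 to compound 4 (0.62 log units; beyond the scatter), so an aromatic ring at this place does not by itself keep a measurable effect. The step from compound 2 to compound 4 cannot be read, as both ends are limits.

Which feature of the two better arms matters remains open. So does whether a carboxylic acid on a benzene ring, or a longer chain carrying the pyridine, would give a number.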